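Aryl swap at the dienone terminus: compound 3 to compound 4

The compounds below may be only part of what the source reports. "The series", "measured", "known", "first", "only" and "open" are said of these compounds alone.

Measured in a functional assay on HCT-116 cells (Homo sapiens) for cytotoxicity, read by sulforhodamine B assay, with a stated time of 48 h; on this read-out lower numbers stand for stronger inhibition and higher numbers for weaker inhibition:
compound 1 `COc1ccccc1/C=C/C(=O)/C=C/c1ccc(OCc2cn(CCOc3cc(=O)oc4ccccc34)nn2)c(OC)c1` gives 9490 nM
compound 2 `COc1ccc(/C=C/C(=O)/C=C/c2ccc(OCc3cn(CCOc4cc(=O)oc5ccccc45)nn3)c(OC)c2)cc1OC` gives 4710 nM
compound 3 `COc1cc(/C=C/C(=O)/C=C/c2cccc3ccccc23)ccc1OCc1cn(CCOc2cc(=O)oc3ccccc23)nn1` gives 6540 nM

The three numbers sit close together. Among the compounds with values here, compound 3 is separated from its neighbours only by a 1.4-fold higher number from compound 2 to compound 3 (0.14 log units; within the scatter) and by a 1.5-fold lower number from compound 1 to compound 3 (0.16 log units; within the scatter), so no compound can be set apart from the others on these data.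

The next compound, compound 4 `COc1cc(/C=C/C(=O)/C=C/c2cccs2)ccc1OCc1cn(CCOc2cc(=O)oc3ccccc23)nn1`, differs from compound 3 in one place: thiophen-2-yl in place of naphthalen-1-yl on a double-bonded chain carbon bound to a double-bonded chain carbon

All three measured steps bear on this change, since each replaces the aryl group at the same position on the chain: a 2.0-fold lower number from compound 1 to compound 2 (0.30 log units; within the scatter), a 1.5-fold lower number from compound 1 to compound 3 (0.16 log units; within the scatter) and a 1.4-fold higher number from compound 2 to compound 3 (0.14 log units; within the scatter). None of them moved the number beyond the scatter. Nothing measured here says that a smaller five-membered aromatic ring with one hetero atom should behave differently from the three aryl groups already tried, so the expected step from compound 3 to compound 4 is again none beyond the scatter, with an estimated 1.1-fold higher number from compound 3 to compound 4 (0.03 log units; within the scatter).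

On that basis compound 4 is estimated to give about 7000 nM in this assay, within a range of 2500 nM to 20000 nM.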

Compound 4, half-maximal inhibitory concentration: 9290 nM
Compound 4: middle estimate off by 1.3-fold (0.12 log units), on the low side; measured number inside the range.
By their numbers in this assay, from the lowest: compounds 2, 3, 4 and 1 (each within the scatter of the next).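

In this assay, thiophen-2-yl brings the first five-membered aromatic ring with a hetero atom to this position, with fewer heavy atoms than naphthalen-1-yl, yet the step stays within the scatter (a 1.4-fold higher number from compound 3 to compound 4 (0.15 log units; within the scatter)). The comparisons with the two substituted phenyl groups also stay within the scatter (a 2.0-fold higher number from compound 2 to compound 4 (0.29 log units; within the scatter); a 1.0-fold lower number from compound 1 to compound 4 (0.01 log units; within the scatter)), so on a double-bonded chain carbon bound to a double-bonded chain carbon, the series now spans one and two aromatic rings, and carbon-only and sulfur-containing rings, without any aryl group being set apart. No accompanying measurement helps to interpret this flat result.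

The aryl groups shown carry only methoxy substituents or none, so it remains open whether an amine or a carboxylic acid on the aryl group at this position would move the number beyond the scatter. It also remains open whether a longer chain elsewhere in the shared core would shift the numbers of these compounds, since all four compounds share that core unchanged.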